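Pyridyl urea series: nitrile-to-chloro swap at the amide nitrogen

A few compounds are considered here, and "the series" means these few. Any claim that something is new, unique, unknown or untested is made for them only; others in the source may bear on it.

Compound 1 `Cc1cc(CNC(=O)Nc2cc(Cl)nc(OCC(F)F)c2)nnc1-c1cn(C)nc1C(F)(F)F` and compound 2 `CCOc1cc(NC(=O)NCc2cc(C)c(-c3cn(C)nc3C(F)(F)F)nn2)cc(C#N)n1` share the core and differ only in the pyridyl group on the urea. In a functional assay on CHO cells for antagonist activity at sphingosine 1-phosphate receptor 2 (Homo sapiens), read by scintillation counting and GTPgammaS binding, with a stated time of 4 h, in the presence of a further agent that is not named here (a lower number here means a stronger inhibitor, a higher number a weaker inhibitor), compound 1 gives 36 nM and compound 2 gives 35 nM; the two numbers lie within the scatter of each other, so no order can be read between them. Compound 3 `CCOc1nc(C)cc(NC(=O)NCc2cc(C)c(-c3cn(C)nc3C(F)(F)F)nn2)c1Cl` carries 3-chloro-2-ethoxy-6-methylpyridin-4-yl in place of 2-cyano-6-ethoxypyridin-4-yl on an amide-type nitrogen. Within the data shown here, no step between measured compounds covers this change. For compound 3 a small weakening is expected in this assay, as a 1.7-fold higher number from compound 2 to compound 3 (0.23 log units; within the scatter), with an estimated 60 nM in the range 20 nM to 200 nM.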

Compound 3, half-maximal inhibitory concentration: 26 nM
Compound 3: middle estimate off by 2.3-fold (0.36 log units), on the high side, and the stated range covers the measured number.
By their numbers in this assay, from the lowest: compounds 3, 2 and 1 (each within the scatter of the next).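

In this assay, 3-chloro-2-ethoxy-6-methylpyridin-4-yl in place of 2-cyano-6-ethoxypyridin-4-yl on an amide-type nitrogen reads as a 1.3-fold lower number from compound 2 to compound 3 (0.13 log units; within the scatter). This position on the urea therefore accepts loss of the nitrile, with a chlorine and a methyl entering together, without the number leaving the scatter. Nothing available bears on why the numbers stay together.

Going by these compounds, the chlorine and the methyl enter in one step, so their separate contributions stay open. Also open, on these data alone, is whether a carboxylic acid or an amine on this pyridyl group would keep the number in the same range.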